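Swapping methyl for methoxy on a weakly cytotoxic scaffold

The source may report more compounds than this note shows. Statements on the series, on what has been measured and on what is new or still open speak of the compounds shown alone.

Measured compounds:
compound 1 `COc1ccc(Nc2nc3ccccc3nc2S(=O)(=O)c2ccc(C)cc2)cc1`: > 50000 nM
compound 2 `Cc1ccc(S(=O)(=O)c2nc3ccccc3nc2Nc2ccc(F)cc2)cc1`: 39200 nM
compound 3 `Cc1ccc(S(=O)(=O)c2nc3ccccc3nc2Nc2ccc(C(F)(F)F)cc2)cc1`: 13500 nM

In a functional assay on A549 cells (Homo sapiens) for cytotoxicity, read by MTT assay, with a stated time of 72 h (on this read-out lower numbers stand for stronger inhibition and higher numbers for weaker inhibition), compound 1 reaches only the limit of the assay, > 50000 nM, so its true value is not known. Compound 2 gives 39200 nM and compound 3 gives 13500 nM. Both differ from compound 1 on the ring bearing the amine, with an at least 1.2-fold lower number from compound 1 to compound 2 (0.10 log units; that floor lies within the scatter), an at least 3.7-fold lower number from compound 1 to compound 3 (0.56 log units; beyond the scatter) and a 2.9-fold lower number from compound 2 to compound 3 (0.46 log units; beyond the scatter). Compound 4 `COc1ccc(Nc2nc3ccccc3nc2S(=O)(=O)c2ccc(OC)cc2)cc1` instead alters a different ring: methoxy in place of methyl on an aromatic carbon. Among the measured compounds shown here, no measured step touches that ring, so the measured steps give no direct guide. The expectation is therefore no shift beyond the scatter, a step that the limit leaves unreadable from compound 1 to compound 4. Compound 4 is estimated at 60000 nM, between 25000 nM and 200000 nM, and may well again register only as a limit.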

Compound 4, half-maximal inhibitory concentration: 8260 nM
The estimate for compound 4 lay 7.3-fold (0.86 log units) above the measured number; the whole stated range lies above it.
By their numbers in this assay, from the lowest: compounds 4 and 3 (each within the scatter of the next); then compound 2. At a limit, above all of these: compound 1.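

Among the compounds shown here, the ring carrying the 4-methylphenyl group, untouched by the earlier steps, also matters: in this assay, methoxy in place of methyl, para to a large group, gives an at least 6.0-fold lower number from compound 1 to compound 4 (0.78 log units; beyond the scatter). This shows that the change reaches beyond the scatter, even though only a minimum size can be read. Compound 1 gives > 50000 nM, which is a limit and not a number, so the true size of the step stays unknown: the limit of > 50000 nM in this assay, at which 1 of the 4 values shown sits.

On these data alone, how a hydroxyl, a carboxylic acid or a longer chain would read at this position remains open. Also open, as far as these compounds go, is whether methoxy here would combine with fluoro or trifluoromethyl on the ring bearing the amine.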